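The source may hold more compounds than are shown below. What is called first, only, known or untested is meant among the compounds shown, and "the series" means these compounds.

Measured so far in a functional assay on HBL-100 cells (Homo sapiens) for inhibition, read by sulforhodamine B assay, with a stated time of 48 h; on this read-out lower numbers stand for stronger inhibition of growth and higher numbers for weaker inhibition of growth:
- Compound 1 `COC(=[Se])Nc1ccc2c(C)cc(=O)oc2c1`: > 100000 nM, a limit of the assay
- Compound 2 `Cc1cc(=O)oc2cc(NC(=[Se])Nc3ccccc3)ccc12`: 28000 nM

Going by the values given here, compound 2 holds the only true number, so there is no measured number to rank it against. Compound 1 stands at a limit.

Compound 3 `Cc1cc(=O)oc2cc(NC(=[Se])Nc3ccc(Br)cc3)ccc12` differs from compound 2 by bromo in place of hydrogen on an aromatic carbon, that is, phenyl to 4-bromophenyl. Among the compounds with values here, only one measured step is available, an at least 3.5-fold lower number from compound 1 to compound 2 (0.55 log units; beyond the scatter), which put anilino in place of methoxy. Within the data shown here, it bears on this change only indirectly, since no measured step involves a substituent on that aromatic ring. A small shift towards lower numbers is therefore expected in this assay, possibly not much beyond the scatter. The estimated step is a 1.8-fold lower number from compound 2 to compound 3 (0.24 log units; within the scatter). For compound 3 the expected value is 16000 nM, with an estimated range of 5000 nM to 50000 nM.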

Compound 3, concentration for 50% growth inhibition: 2200 nM
Compound 3: middle estimate off by 7.3-fold (0.86 log units), on the high side; the measured number lies below the stated range.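

In this assay, phenyl to 4-bromophenyl gives a 13-fold lower number from compound 2 to compound 3 (1.10 log units; beyond the scatter). Going by these compounds alone, this is the only measured step on that aromatic ring, and it shows that the ring is not a silent place: a single bromine atom on an aromatic carbon, para to a large group, is enough to give a large step. No measured property in hand accounts for the size of this step.

A single substituent cannot show whether the step belongs to bromo itself or would also appear with chloro, nitrile or an amine at the same place. Also open, as far as these compounds go, is whether bromo elsewhere on that ring, or on a longer chain between the ring and the shared core, would give a step of similar size.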